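This account rests on a few compounds, and the source may have more. Where it says the series, first, only, none or still open, it means among the compounds named here.

Compound 1, `Cc1cn([C@@H]2O[C@H](CO[Si](C)(C)C(C)(C)C)[C@@]3(OS(=O)(=O)C=C3NCC(N)=O)[C@H]2O[Si](C)(C)C(C)(C)C)c(=O)n(C)c1=O`, is measured in a functional assay on CCRF-CEM cells (Homo sapiens) (a higher number here means that more compound is tolerated, a lower number that less compound is tolerated), where compound 1 gives 14600 nM. Among the three compounds with numbers, compound 1 has the lowest. Compound 2, `CC(=O)NC1=CS(=O)(=O)O[C@@]12[C@@H](CO[Si](C)(C)C(C)(C)C)O[C@@H](n1cc(C)c(=O)n(C)c1=O)[C@@H]2O[Si](C)(C)C(C)(C)C`, carries acetyl in place of carbamoylmethyl on the amine nitrogen and gives 25700 nM in this assay; the step is a 1.8-fold higher number from compound 1 to compound 2 (0.25 log units; within the scatter). Compound 3, `COC(=O)NC1=CS(=O)(=O)O[C@@]12[C@@H](CO[Si](C)(C)C(C)(C)C)O[C@@H](n1cc(C)c(=O)n(C)c1=O)[C@@H]2O[Si](C)(C)C(C)(C)C`, carries methoxycarbonyl there and gives 30700 nM in this assay, so that a 2.1-fold higher number from compound 1 to compound 3 (0.32 log units; beyond the scatter). Between the two, a 1.2-fold higher number from compound 2 to compound 3 (0.08 log units; within the scatter).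

Compound 4, `Cc1cn([C@@H]2O[C@H](CO[Si](C)(C)C(C)(C)C)[C@@]3(OS(=O)(=O)C=C3NCC(=O)C(=O)O)[C@H]2O[Si](C)(C)C(C)(C)C)c(=O)n(C)c1=O`, differs from compound 1 in one place: carboxy in place of amino on a carbonyl carbon. Going by the values given here, the steps that bear on this are the three above, all of which alter the same amine substituent or the group on its carbonyl carbon, and none of them moves this assay by more than a modest amount; two lie within the scatter and the third only just beyond it. The change to compound 4 keeps the carbamoylmethyl chain but replaces its terminal amino by carboxy, which is a change of similar scope. An expectation of at most a small rise is therefore drawn, a 1.3-fold higher number from compound 1 to compound 4 (0.11 log units; within the scatter). Compound 4 is estimated to give 19000 nM in this assay, within a range of 7000 nM to 50000 nM.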

Compound 4, half-maximal cytotoxic concentration: 72600 nM
Estimate against measurement, compound 4: 3.8-fold (0.58 log units) below; measured number outside the range, above it.
By their numbers in this assay, from the lowest: compounds 1, 2 and 3 (each within the scatter of the next, the first and the last beyond it); then compound 4.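

Carboxy in place of amino on a carbonyl carbon moves this assay further than any step among the earlier compounds (a 5.0-fold higher number from compound 1 to compound 4 (0.70 log units; beyond the scatter)), so a change at the far end of the carbamoylmethyl chain proves able to shift the number well beyond the scatter. Compound 4 also stands apart from the two compounds with a carbonyl directly on the amine nitrogen (a 2.8-fold higher number from compound 2 to compound 4 (0.45 log units; beyond the scatter); a 2.4-fold higher number from compound 3 to compound 4 (0.37 log units; beyond the scatter)), which makes it the compound with the highest number of the four, and the substituent on this nitrogen therefore has more effect on the read-out than compounds 1, 2 and 3 alone suggested. Nothing available explains why this replacement raises the number so much.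

The compounds shown leave open whether the rise belongs to the carboxylic acid itself or to the (carboxycarbonyl)methyl chain as a whole, a question that a methyl ester at that end, or a plain carboxymethyl group on the amine nitrogen, would bear on. They also leave open how a longer chain ending in carboxy would read in this assay on the same core.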